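The source may hold more compounds than are shown below. What is called first, only, known or untested is meant among the compounds shown, and "the series" means these compounds.

In a functional assay on a cell-free system (plasma, Homo sapiens), with a stated time of 3 min (on this read-out lower numbers stand for stronger inhibition and higher numbers for weaker inhibition), two compounds have been measured so far. Compound 1 `Cc1cccc([C@@H](O)C(=O)N2N=CC[C@H]2C(=O)NCc2cc(Cl)ccc2-n2cnnn2)c1` gives 830 nM, and compound 2 `O=C(NCc1cc(Cl)ccc1-n1cnnn1)[C@@H]1[C@H]2C[C@H]2CN1C(=O)[C@H](O)c1ccccc1` gives 960 nM. These two values lie within the usual scatter of each other, so compound 2 stands level with compound 1 and neither can be ranked above the other.

The next compound to be read is compound 3 `O=C(NCc1cc(Cl)ccc1-n1cnnn1)[C@@H]1[C@H]2C[C@H]2CN1C(=O)[C@H](O)Cc1ccccc1`, which differs from compound 2 in one place: benzyl in place of phenyl on a saturated chain carbon bound to a carbonyl carbon and an oxygen on a saturated carbon. In other words, hydroxy(phenyl)methyl becomes 1-hydroxy-2-phenylethyl, with benzyl in place of phenyl on a saturated chain carbon bound to a carbonyl carbon and an oxygen on a saturated carbon.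

Among the measured compounds shown here, no measured pair shows this change, so the expectation is a judgement anchored only on compound 2 at 960 nM. A moderate move toward weaker inhibition, beyond the scatter, is what is anticipated, though a result level with compound 2 would not be surprising. The expected size of the move is a 2.6-fold higher number from compound 2 to compound 3 (0.42 log units; beyond the scatter). For compound 3 the estimated value is 2500 nM, with an expected range from 800 nM to 8000 nM.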

Compound 3, half-maximal inhibitory concentration: 1200 nM
The estimate for compound 3 lay 2.1-fold (0.32 log units) above the measured number, and the stated range covers the measured number.
By their numbers in this assay, from the lowest: compounds 1, 2 and 3 (each within the scatter of the next).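

In this assay, benzyl in place of phenyl on a saturated chain carbon bound to a carbonyl carbon and an oxygen on a saturated carbon gives a 1.3-fold higher number from compound 2 to compound 3 (0.10 log units; within the scatter) and so the two compounds stand level. Among the compounds shown here, this is the first pair that differs in one place, and it shows that, on this read-out, hydroxy(phenyl)methyl and 1-hydroxy-2-phenylethyl cannot be told apart on this core, with the added carbon leaving the number within the scatter. No measurement at hand offers a reason for this result.

From the compounds shown here alone, whether a longer chain carrying the phenyl ring, or an amine or a carboxylic acid at the end of the chain, would also stay level with compound 2 remains open. The compounds shown also leave open whether the same change would read alike on the core of compound 1, and whether the hydroxy group on this carbon could be replaced by a methoxy group or a hydrogen without moving the number.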